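The compounds below may be only part of what the source reports. "The series", "measured", "known", "first", "only" and "open" are said of these compounds alone.

Measured so far in an ADME assay on microsomes from liver (Homo sapiens) for metabolic stability, read by LC-MS, with a stated time of 60 min (on this read-out higher numbers stand for a more stable compound and lower numbers for a less stable compound), are two compounds:
Compound 1 `NC(=O)c1cnc2c(c1Cl)CCN2` gives 57%
Compound 2 `C[C@H]1Nc2ncc(C(N)=O)cc2[C@@H]1C` gives "unstable" (no number reported)

Among the compounds with values here, compound 1 holds the only number here, as compound 2 was reported in words alone, so compound 1 cannot be ranked against any measured neighbour. Compound 3 `Cc1c(C(N)=O)cnc2c1CCN2` keeps the core of compound 1 and differs by methyl in place of chloro on an aromatic carbon on an aromatic carbon. Within the data shown here, no measured step exists to size this change. Only a small downward move is expected, possibly within the usual scatter. The estimated shift is a number 7 percentage points lower from compound 1 to compound 3 (within the scatter) in this assay as an expectation only. For compound 3 the estimated value is 50% with an expected range from 28% to 72% once measured.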

Compound 3, percent of the compound remaining: 85%
Estimate against measurement, compound 3: 35 percentage points below, and the stated range ends below it.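

In this assay, within the data shown here, methyl in place of chloro on an aromatic carbon opposite the ring nitrogen gives a number 28 percentage points higher from compound 1 to compound 3 (beyond the scatter), the first step that can be read on this core. Exchanging one heavy atom for another at this position is thus enough to move the read-out beyond the usual scatter. Nothing at hand bears on why the number moved.

The compounds shown do not tell how an ethyl group, a methoxy group or an amine would read at this position. On these data alone, whether the step would hold on another core also remains open.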